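The source may report more compounds than this note shows. Statements on the series, on what has been measured and on what is new or still open speak of the compounds shown alone.

Measured so far:
compound 1 `CN(C)CCn1cnnc1-c1cc(Oc2ccc(NC(=O)N/N=C/c3ccccc3O[N+](=O)[O-])cc2F)ccn1` — 7150 nM
compound 2 `CN(C)CCn1cnnc1-c1cc(Oc2ccc(NC(=O)N/N=C/c3ccc(O)c(O)c3)cc2F)ccn1` — > 100000 nM
compound 3 `CN(C)CCn1cnnc1-c1cc(Oc2ccc(NC(=O)N/N=C/c3c(O)ccc4ccccc34)cc2F)ccn1` — 620 nM

All three share one core and differ only in the aryl group hanging on the carbon that is double-bonded to nitrogen. In a functional assay on U-87MG ATCC cells (Homo sapiens) for cytotoxicity, read by MTT assay, with a stated time of 72 h (on this read-out higher numbers stand for weaker inhibition and lower numbers for stronger inhibition), compound 3 has the lowest number of the two numbers shown. For compound 2 the value is a limit of this assay, not a number (the limit of > 100000 nM in this assay, at which 1 of the 3 values shown sits). The steps of a 12-fold lower number from compound 1 to compound 3 (1.06 log units; beyond the scatter) and an at least 160-fold lower number from compound 2 to compound 3 (2.20 log units; beyond the scatter) are both large, so this position matters strongly.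

Compound 4 `CN(C)CCn1cnnc1-c1cc(Oc2ccc(NC(=O)N/N=C/c3cccc(O)c3)cc2F)ccn1` makes the change (3-hydroxyphenyl in place of 2-hydroxynaphthalen-1-yl on a carbon with a double bond to nitrogen). This removes one of the two six-membered aromatic rings and moves the hydroxyl. The step from compound 3 to compound 4 is therefore expected to be large, towards a higher number, namely a 16-fold higher number from compound 3 to compound 4 (1.21 log units; beyond the scatter). Compound 4 is expected to give about 10000 nM, estimated between 2000 nM and 50000 nM.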

Compound 4, half-maximal inhibitory concentration: > 100000 nM
Compound 4 ended at the assay's limit; the forecaster's own chance of this, stated with the estimate: 15%; middle value at least 10-fold (1.00 log units) away from the limit.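

Compound 4 gives a limit of this assay, not a number: the limit of > 100000 nM in this assay, at which 2 of the 4 values shown sit.

The step to a single ring bearing a hydroxy group is steep, with an at least 160-fold higher number from compound 3 to compound 4 (2.20 log units; beyond the scatter) on going from 2-hydroxynaphthalen-1-yl, and an at least 13-fold higher number from compound 1 to compound 4 (1.14 log units; beyond the scatter) on going from 2-(nitrooxy)phenyl. So a hydroxy group on one ring is not enough here, as compound 2 and compound 4 both sit at the limit, and the step between those two cannot be read.

Going by these compounds, compound 3 differs from compound 4 in both its second ring and its hydroxy placement, so which one matters stays open. A 2-hydroxyphenyl or a plain naphthalen-1-yl group would help separate them.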